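This account rests on a few compounds, and the source may have more. Where it says the series, first, only, none or still open, it means among the compounds named here.

In an assay on isolated protein for inhibition of Rho-associated protein kinase 2 (Homo sapiens), read by radiometric assay and 33P incorporation, with a stated time of 40 min, in the presence of a further agent that is not named here (a higher number here means a weaker inhibitor, a lower number a stronger inhibitor), compound 2 `COc1cccc(Cn2cnc3sc(-c4ccnc(Cl)c4)cc3c2=O)c1` gives 501 nM, the second highest of the three numbers. Compound 1 `COc1cccc(CN2CCc3cc(-c4ccc5[nH]ncc5c4)ccc3C2=O)c1` gives 632 nM, within the scatter of compound 2, while compound 3 `COc1cccc(Cn2cnc3sc(-c4ccnc(C)c4)cc3c2=O)c1` gives 42 nM. Among the compounds with values here, the only one-place step among the measured compounds is a 12-fold lower number from compound 2 to compound 3 (1.08 log units; beyond the scatter), a change made within the same group that compound 4 replaces. Compound 4 `COc1cccc(Cn2cnc3sc(-c4ccc(N)nc4)cc3c2=O)c1` differs from compound 2 by 6-aminopyridin-3-yl in place of 2-chloropyridin-4-yl on an aromatic carbon. Within the data shown here, since this change also does away with the chloro of compound 2, the step from compound 2 to compound 3 bears on it, though the new group is attached differently and carries an amino group, which no measured pair covers. A lower number is therefore expected, estimated as an 8.4-fold lower number from compound 2 to compound 4 (0.92 log units; beyond the scatter). Compound 4 is expected to give 60 nM in this assay, with a range of 15 nM to 250 nM.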

Compound 4, half-maximal inhibitory concentration: > 10000 nM
Compound 4: only a limit was reported; the forecaster's own chance of this, stated with the estimate: 2%; at least 160-fold (2.22 log units) between middle value and limit.
By their numbers in this assay, from the lowest: compound 3; then compounds 2 and 1 (each within the scatter of the next). At a limit, above all of these: compound 4.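

Compound 4 is reported only as a limit of the assay, not as a number: the limit of > 10000 nM in this assay, at which 1 of the 4 values shown sits. At this place, on an aromatic carbon next to the ring sulfur, this assay gives an at least 19-fold higher number from compound 2 to compound 4 (1.30 log units; beyond the scatter) and an at least 230-fold higher number from compound 3 to compound 4 (2.37 log units; beyond the scatter). The earlier compounds shown here showed only a gain at this place, from methyl in place of chloro, whereas 6-aminopyridin-3-yl shows that a change here can also go sharply the other way.

Whether the amino group or the different attachment of the pyridine accounts for this stays open, as the two change together in compound 4. A 2-aminopyridin-4-yl group or an unsubstituted pyridin-3-yl group would separate them.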